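The compounds below may be only part of what the source reports. "The series", "measured", "known", "first", "only" and "open" are said of these compounds alone.

Measured compounds:
compound 1, `OC[C@H]1O[C@@H](n2cnc3c(CSc4ccc(Br)cc4)ncnc32)[C@H](O)[C@@H]1O` — 178 nM
compound 2, `N#Cc1ccc(SCc2ncnc3c2ncn3[C@@H]2O[C@H](CO)[C@@H](O)[C@H]2O)cc1` — 81.3 nM
compound 3, `OC[C@H]1O[C@@H](n2cnc3c(CSc4ccc(F)cc4)ncnc32)[C@H](O)[C@@H]1O` — 158 nM

All three share one core and differ only in the group on the aromatic carbon para to a large group. In an assay on isolated protein for binding affinity to Equilibrative nucleoside transporter 1 (Homo sapiens) (on this read-out higher numbers stand for weaker inhibition and lower numbers for stronger inhibition), compound 3 gives 158 nM. Compound 1 gives 178 nM in this assay, and the step of a 1.1-fold lower number from compound 1 to compound 3 (0.05 log units; within the scatter) is within the scatter. Compound 2 gives 81.3 nM in this assay, and the step of a 1.9-fold higher number from compound 2 to compound 3 (0.29 log units; within the scatter) is likewise within the scatter, so compound 3 is not separated from either of its companions. Among the measured compounds shown here, the only step beyond the scatter among the three is a 2.2-fold lower number from compound 1 to compound 2 (0.34 log units; beyond the scatter), and it is modest.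

Compound 4, `OC[C@H]1O[C@@H](n2cnc3c(CSc4ccc(OC(F)(F)F)cc4)ncnc32)[C@H](O)[C@@H]1O`, carries trifluoromethoxy in place of fluoro on an aromatic carbon. The steps bearing on this change are the three exchanges at the same carbon, a 1.1-fold lower number from compound 1 to compound 3 (0.05 log units; within the scatter), a 1.9-fold higher number from compound 2 to compound 3 (0.29 log units; within the scatter) and a 2.2-fold lower number from compound 1 to compound 2 (0.34 log units; beyond the scatter), none of them more than modest. On that basis no step beyond the scatter is expected in this assay; the estimated step is a 1.1-fold lower number from compound 3 to compound 4 (0.02 log units; within the scatter). Compound 4 is therefore expected to give 150 nM, with a range from 60 nM to 400 nM.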

Compound 4, half-maximal inhibitory concentration: 123 nM
The estimate for compound 4 lay 1.2-fold (0.09 log units) above the measured number; the range from low to high includes it.
By their numbers in this assay, from the lowest: compounds 2, 4, 3 and 1 (each within the scatter of the next, the first and the last beyond it).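

In this assay, trifluoromethoxy, at 5 heavy atoms against 1 for fluoro, stands on this aromatic carbon para to a large group with no step beyond the scatter (a 1.3-fold lower number from compound 3 to compound 4 (0.11 log units; within the scatter)), and the same holds against bromo (a 1.4-fold lower number from compound 1 to compound 4 (0.16 log units; within the scatter)) and against cyano (a 1.5-fold higher number from compound 2 to compound 4 (0.18 log units; within the scatter)). Among the four groups now shown at this carbon, the only step beyond the scatter remains the modest one between bromo and cyano (a 2.2-fold lower number from compound 1 to compound 2 (0.34 log units; beyond the scatter)), and compound 4 is not separated from any of the other three. No supporting measurement is available to explain these numbers.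

Still open, as far as these compounds go, is whether an amine, a carboxylic acid or a longer chain at this carbon would give a larger step. The compounds shown also leave open how changes at other places on the aromatic ring would read.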